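A methyl removed where every measurement is a limit

A few compounds are considered here, and "the series" means these few. Any claim that something is new, unique, unknown or untested is made for them only; others in the source may bear on it.

Of the compounds shown here, three that share one core have been tested in a functional assay on NCI-H322M cells (Homo sapiens) for inhibition, read by sulforhodamine B assay, with a stated time of 48 h; a higher number here means that more compound is tolerated, a lower number that less compound is tolerated. Compound 1 `COc1cc(-c2nn(-c3cccc(NC(=O)c4ccc(Cl)c(C(F)(F)F)c4)c3)cc2-c2ccncc2)ccc1Cl` gives > 32500 nM in this assay, and this is a limit of the assay rather than a number. Compound 2 `COc1cc(-c2nn(-c3cccc(NC(=O)Nc4ccc(Cl)c(C(F)(F)F)c4)c3)cc2-c2ccncc2)ccc1Cl` likewise reaches only a limit in this assay, > 32500 nM. Compound 3 `COc1cc(-c2nn(-c3cccc(NC(=O)c4ccccc4)c3)cc2-c2ccncc2)ccc1Cl` also stops at a limit in this assay, > 100000 nM. With every value a limit, the steps between the three are unreadable: a step that the two limits leave unreadable from compound 1 to compound 2, a step that the two limits leave unreadable from compound 1 to compound 3 and a step that the two limits leave unreadable from compound 2 to compound 3. Compound 2 therefore stands at a limit alongside the others, as shown by the limit of > 32500 nM in this assay, at which 2 of the 3 values shown sit, and (the limit of > 100000 nM in this assay, at which 1 of the 3 values shown sits).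

Compound 4 `O=C(Nc1cccc(-n2cc(-c3ccncc3)c(-c3ccc(Cl)c(O)c3)n2)c1)Nc1ccc(Cl)c(C(F)(F)F)c1` differs from compound 2 in a single place: hydrogen in place of methyl on an oxygen on an aromatic ring. For the measured compounds named here, none of the measured steps changes this oxygen, so no measured step bears directly on the change, and each of them is in any case unreadable in size. With every measured neighbour at a limit, there is nothing to suggest a shift beyond the scatter in either direction. Compound 4 is thus expected to remain at a limit, the expected step being a step that the limit leaves unreadable from compound 2 to compound 4. The estimate for compound 4 in this assay is 50000 nM, within a range from 20000 nM to 150000 nM.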

Compound 4, concentration lethal to 50% of the cells: 24700 nM
For compound 4 the middle estimate is 2.0-fold (0.31 log units) above the measured one; measured number inside the range.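

In this assay, for the compounds shown here, compound 4 gives 24700 nM, the only value among the four compounds that is a number rather than a limit, so the series now has one reading against which other changes could be sized. Compound 2 gives > 32500 nM, and this is a limit of the assay. The change of methoxy to hydroxy on the aromatic ring gives an at least 1.3-fold lower number from compound 2 to compound 4 (0.11 log units; that floor lies within the scatter), so it can be read only as a minimum: the true step may be larger, or there may be no real change at all, while the steps among compounds 1, 2 and 3 cannot be read.

An ethyl group or a longer chain on this oxygen, or an amine in place of the hydroxy, would help show whether the reading depends on the hydrogen on the oxygen or simply on the absence of the methyl. On these data alone, it also remains open whether the same methoxy to hydroxy change would turn the limits of compound 1 and compound 3 into numbers.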